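This account rests on a few compounds, and the source may have more. Where it says the series, first, only, none or still open, it means among the compounds named here.

Compound 3 `CCN(CC)CCCNc1nc(-c2ccc(NC(=O)Nc3ccccc3)cc2)nc2ccsc12` is a urea-bearing analogue tested in a functional assay on MDA-MB-231 cells (Homo sapiens) for cytotoxicity, read by MTT assay, with a stated time of 72 h; a lower number here means a stronger inhibitor, a higher number a weaker inhibitor; in it compound 3 gives 1230 nM, the lowest of the three numbers. Compound 1 `CN(C)CCNc1nc(-c2ccc(NC(=O)Nc3ccccc3)cc2)nc2ccsc12` gives 1310 nM, and the step of a 1.1-fold lower number from compound 1 to compound 3 (0.03 log units; within the scatter) lies within the scatter, so neither can be called stronger. Compound 2 `CN(C)CCCNc1nc(-c2ccc(NC(=O)Nc3ccc(Cl)cc3Cl)cc2)nc2c(Cl)c(Cl)sc12` gives 3490 nM, a higher number beyond the scatter, but it differs from compound 3 in several places at once. Compound 4 `CCN(CC)CCCNc1nc(-c2ccc(NC(=O)Nc3ccccc3Cl)cc2)nc2ccsc12` carries chloro in place of hydrogen on an aromatic carbon. Within the data shown here, no measured step changes only this ring: the single known step, a 1.1-fold lower number from compound 1 to compound 3 (0.03 log units; within the scatter), concerns the amine end and does not bear on it, and compound 2 offers only a value. The step of a 1.2-fold higher number from compound 3 to compound 4 (0.09 log units; within the scatter) is expected to stay within the scatter. The estimate for compound 4 is 1500 nM, from 600 nM to 4000 nM.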

Compound 4, half-maximal inhibitory concentration: 500 nM
Compound 4: middle estimate off by 3.0-fold (0.48 log units), on the high side; the measured number lies below the stated range.
By their numbers in this assay, from the lowest: compound 4; then compounds 3 and 1 (each within the scatter of the next); then compound 2.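

Chloro in place of hydrogen on an aromatic carbon, ortho to a large group, gives a 2.5-fold lower number from compound 3 to compound 4 (0.39 log units; beyond the scatter) in this assay, a modest step but one beyond the scatter. Among these compounds, the only other single-place step, a 1.1-fold lower number from compound 1 to compound 3 (0.03 log units; within the scatter), at the amine end, stayed within the scatter, so this ring position responds to the addition of one chlorine atom where that amine change did not. No measurement shown explains this step.

Going by these compounds, whether a fluoro, methyl or methoxy group at this same place would act like chloro remains open. So does the effect of chloro elsewhere on this ring.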